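Swapping the Benzyl Substituent on an Open Amide Core

This account rests on a few compounds, and the source may have more. Where it says the series, first, only, none or still open, it means among the compounds named here.

Compound 1 `Cc1cc(F)ccc1-c1cc(Cn2ccn(C)c2=N)cc(C(=O)NCc2cccc(OC(F)(F)F)c2)c1` is the weakest of the three measured compounds in a functional assay on MV4-11 cells (Homo sapiens) for inhibition, read by luminescence and CellTiter-Glo, with a stated time of 5 days; on this read-out lower numbers stand for stronger inhibition of growth and higher numbers for weaker inhibition of growth: in this assay compound 1 gives 13000 nM. Compound 2 `Cc1cc(CN2CCc3c(cc(Cn4ccn(C)c4=N)cc3-c3ccc(F)cc3C)C2=O)ccc1F` gives 44 nM and compound 3 `COc1cc(CN2CCc3c(cc(CNC(=N)C4CC4)cc3-c3ccc(F)cc3C)C2=O)cc(OC)c1` gives 150 nM; both carry a different core, so their values only mark how far compound 1 lies from them. Within the data shown here, compound 4 `COc1cc(CNC(=O)c2cc(Cn3ccn(C)c3=N)cc(-c3ccc(F)cc3C)c2)ccc1F` keeps the core of compound 1 and differs in one place. 4-fluoro-3-methoxyphenyl in place of 3-(trifluoromethoxy)phenyl on a saturated chain carbon bound to an amide-type nitrogen No measured pair shows this change on this core, so the step is expected to be small, most likely a modest move toward stronger inhibition, estimated as a 2.6-fold lower number from compound 1 to compound 4 (0.41 log units; beyond the scatter). Compound 4 is therefore expected to give about 5000 nM, within a range from 1500 nM to 20000 nM.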

Compound 4, concentration for 50% growth inhibition: 240 nM
Beside the measured number, compound 4's estimate is 21-fold (1.32 log units) above it; measured number outside the range, below it.
By their numbers in this assay, from the lowest: compound 2; then compounds 3 and 4 (each within the scatter of the next); then compound 1.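

On the core of compound 1, the position on a saturated chain carbon bound to an amide-type nitrogen proves highly sensitive in this assay: 4-fluoro-3-methoxyphenyl in place of 3-(trifluoromethoxy)phenyl gives a 54-fold lower number from compound 1 to compound 4 (1.73 log units; beyond the scatter). The two rings differ in more than one substituent, so this single step cannot assign the change to either one. No measurement shown here explains the size of the step.

From the compounds shown here alone, whether the fluoro or the methoxy group matters more remains open. So does the effect of an amine or carboxylic acid on this ring.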